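Compound 4 Judged from the Step out of Compound 2

The compounds below may be only part of what the source reports. "The series", "measured", "known", "first", "only" and "open" are said of these compounds alone.

Measured compounds:
- compound 1, `COc1cccc(/C=C/C(=O)c2ccccc2NC(=O)NS(=O)(=O)c2ccc(C)cc2)c1`, 23.2 ug/mL
- compound 2, `CCOc1cc(/C=C/C(=O)c2ccccc2NC(=O)NS(=O)(=O)c2ccc(C)cc2)ccc1O`, 19.2 ug/mL
- compound 3, `COc1cc(/C=C/C(=O)c2ccccc2NC(=O)NS(=O)(=O)c2ccc(C)cc2)ccc1O`, 17.8 ug/mL

In an ADME assay on the whole organism for cytotoxicity, with Artemia salina as the target, with a stated time of 24 h (on this read-out higher numbers stand for an effect only at larger amounts of compound and lower numbers for an effect already at smaller amounts), compound 2 gives the second highest of the three numbers; its nearest neighbour is compound 3, by a 1.1-fold lower number from compound 2 to compound 3 (0.03 log units; within the scatter), and its furthest is compound 1, by a 1.2-fold lower number from compound 1 to compound 2 (0.08 log units; within the scatter), so the three compounds sit together within the scatter. The unmeasured compound 4, `Cc1ccc(S(=O)(=O)NC(=O)Nc2ccccc2C(=O)/C=C/c2ccncc2)cc1`, differs from compound 2 by pyridin-4-yl in place of 3-ethoxy-4-hydroxyphenyl on a double-bonded chain carbon bound to a double-bonded chain carbon.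

Among the compounds with values here, the only measured step at the same place is the one from compound 1 to compound 2, which exchanged one aryl group for another and stayed within the scatter; the step from compound 1 to compound 3, a 1.3-fold lower number from compound 1 to compound 3 (0.12 log units; within the scatter), also changed only this ring and stayed within the scatter. Within the data shown here, no measured step introduces a pyridin-4-yl, so the data give no guide beyond the observation that changes on this ring have so far left the number in this assay essentially unmoved. Compound 4 is therefore expected to show a 1.0-fold higher number from compound 2 to compound 4 (0.02 log units; within the scatter), no step beyond the scatter. The estimate for compound 4 is 20 ug/mL, with a range from 9 ug/mL to 45 ug/mL.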

Compound 4, concentration for half-maximal effect: 16.8 ug/mL
Compound 4: middle estimate off by 1.2-fold (0.08 log units), on the high side; the range from low to high includes it.
By their numbers in this assay, from the lowest: compounds 4, 3, 2 and 1 (each within the scatter of the next).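

Across this assay, pyridin-4-yl on a double-bonded chain carbon bound to a double-bonded chain carbon gives a 1.1-fold lower number from compound 2 to compound 4 (0.06 log units; within the scatter) and a 1.1-fold lower number from compound 3 to compound 4 (0.03 log units; within the scatter) and also a 1.4-fold lower number from compound 1 to compound 4 (0.14 log units; within the scatter). Within the data shown here, the earlier steps at this place exchanged only one aromatic ring of carbon only for another, whereas these three bring in a smaller ring with a hetero atom and no hydrogen-bond donor, and all four compounds still sit within the scatter of one another. No measured evidence is available to explain this result.

The compounds shown leave open whether a carboxylic acid or a dimethylamino group on this ring, or a saturated piperidin-4-yl in its place, would take the number beyond the scatter. They also leave open what a change elsewhere would do, since all four compounds share the same core.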